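This account rests on a few compounds, and the source may have more. Where it says the series, first, only, none or still open, it means among the compounds named here.

Compound 1 `CNC(=O)c1cn(Cc2ccc(-c3ccccc3)cc2)c2c(OC)c(N3CC[C@@H](CN)C3)c(F)cc2c1=O` — in an assay on isolated protein for inhibition of DNA topoisomerase 1 (Homo sapiens), with a stated time of 15 min (a lower number here means a stronger inhibitor, a higher number a weaker inhibitor), compound 1 gives 82100 nM.
Compound 2 `CNC[C@@H]1CCN(c2cc3c(cc2F)c(=O)c(C(=O)O)cn3Cc2ccc(-n3cccn3)cc2)C1` — for compound 2 this assay reports only a limit, > 200000 nM.

Among the measured compounds shown here, compound 1 therefore stands on the only actual number in this assay. The result for compound 2 is a limit, (the limit of > 200000 nM in this assay, at which 1 of the 2 values shown sits). Compound 3 `COc1c(N2CC[C@@H](CN)C2)c(F)cc2c(=O)c(C(N)=O)cn(Cc3ccc(-c4ccccc4)cc3)c12` differs from compound 1 in one place: hydrogen in place of methyl on an amide-type nitrogen. For the measured compounds named here, no measured pair shows this change, and a change of a single carbon on the amide is expected to move the value no further than the scatter, in no clear direction. Compound 3 is expected to give 80000 nM, within 30000 nM to 200000 nM. This amounts to an expected step of a 1.0-fold lower number from compound 1 to compound 3 (0.01 log units; within the scatter).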

Compound 3, half-maximal inhibitory concentration: 184000 nM
The estimate for compound 3 lay 2.3-fold (0.36 log units) below the measured number; low and high end bracket the measured number.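

In this assay replacing methyl with hydrogen on the amide-type nitrogen gives a 2.2-fold higher number from compound 1 to compound 3 (0.35 log units; beyond the scatter) and so this single carbon does register in the read-out. Among the compounds shown here, this is the only measured pair that isolates the position, and it shows that methylcarbamoyl gives the stronger inhibition of the two, though both numbers remain large. As far as these compounds go, whether an ethyl group or a longer chain on this nitrogen would continue the trend or reverse it stays open. The compounds shown offer no measurement that explains why the methyl matters.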